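Swapping a methoxyphenyl for a chlorophenyl in an orexin agonist series

A few compounds are considered here, and "the series" means these few. Any claim that something is new, unique, unknown or untested is made for them only; others in the source may bear on it.

Measured compounds:
- compound 1, `COc1ccccc1C(=O)NCCNc1cccc(NS(=O)(=O)c2cc(-c3cccc(C(=O)N(C)C)c3)ccc2OC)c1`, 46%
- compound 2, `COc1cccc(C(=O)NCCNc2cccc(NS(=O)(=O)c3cc(-c4cccc(C(=O)N(C)C)c4)ccc3OC)c2)c1`, 49%
- compound 3, `COc1ccc(C(=O)NCCNc2cccc(NS(=O)(=O)c3cc(-c4cccc(C(=O)N(C)C)c4)ccc3OC)c2)cc1`, "not determined" (no result reported)

Three compounds share one core and differ only in the ring attached to a carbonyl carbon. In a functional assay on CHO-K1 cells for agonist activity at Orexin/Hypocretin receptor type 1 (Homo sapiens), read by calcium flux (on this read-out higher numbers stand for larger maximal responses and lower numbers for smaller maximal responses), compound 1 reaches 46% and compound 2 reaches 49%. Among the measured compounds shown here, the one step joining them, a number 3 percentage points higher from compound 1 to compound 2 (within the scatter), stays within the scatter, so moving the methoxy group around that ring changed nothing that can be trusted. Going by these compounds, compound 3 carries the 4-methoxyphenyl variant, and in this assay compound 3 has "not determined" (no result reported), so its own place is unknown.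

Compound 4, `COc1ccc(-c2cccc(C(=O)N(C)C)c2)cc1S(=O)(=O)Nc1cccc(NCCNC(=O)c2ccccc2Cl)c1`, differs from compound 3 by 2-chlorophenyl in place of 4-methoxyphenyl on a carbonyl carbon. For the measured compounds named here, no measured step bears directly on this exchange: the only known step is the one from compound 1 to compound 2, which concerns a methoxy group alone and was within the scatter. The expectation for compound 4 therefore rests on the two measured values sitting close together and on the change being at the same position. Compound 4 is expected to give about 47% in this assay , with a wide range from 25% to 70%.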

Compound 4, largest response reached (Emax), in percent of the reference or control that the assay uses: 50%
For compound 4 the middle estimate is 3 percentage points below the measured one; the range from low to high includes it.
By their numbers in this assay, from the lowest: compounds 1, 2 and 4 (each within the scatter of the next).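

In this assay, putting chloro in place of methoxy on the ring gives a number 4 percentage points higher from compound 1 to compound 4 (within the scatter), and the exchange of 3-methoxyphenyl for 2-chlorophenyl gives a number 1 percentage points higher from compound 2 to compound 4 (within the scatter). The earlier step only moved a methoxy group around the ring, whereas these two steps replace that group with a chlorine atom, so the maximal response fails to separate compounds 1, 2 and 4 even when the group itself is exchanged, not merely shifted. Nothing measured here explains why these exchanges leave the three compounds within the scatter of one another.

Compound 3 has no reported number, so the 4-methoxyphenyl group cannot be placed and its exchange for 2-chlorophenyl cannot be read as a step. Also open, going by these compounds, is whether a very different group on this ring, such as an amine or a carboxylic acid, or a longer chain in place of the ring, would move the response beyond the scatter, since methoxy and chloro cover only a small part of what could sit here.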